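Removing one methyl from a saturated ring carbon

A few compounds are considered here, and "the series" means these few. Any claim that something is new, unique, unknown or untested is made for them only; others in the source may bear on it.

Of the compounds shown here, three have been measured in an assay on cells for inhibition of cytochrome P450 11B2, mitochondrial (Homo sapiens), read by HTRF; a lower number here means a stronger inhibitor, a higher number a weaker inhibitor. Compound 1 `CC1(C)CN(c2cccnc2)C(=O)c2ccc(Cl)cc21` gives 1540 nM. Compound 2 `CC1CN(c2cccnc2)C(=O)c2ccc(Cl)cc21` gives 164 nM. Compound 3 `CC1(C)c2cc(Cl)ccc2C(=O)N1c1cccnc1` gives 108 nM; its number is the lowest of the three, but its gap to compound 2 lies within the usual scatter, so the two cannot be ordered, while its gap to compound 1 lies beyond it.

Among the compounds with values here, the one counted step so far is a 9.4-fold lower number from compound 1 to compound 2 (0.97 log units; beyond the scatter), with hydrogen in place of methyl on a saturated ring carbon. The difference between the core of compound 1 and the core of compound 3 is not broken down here.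

Compound 4 `CC1c2cc(Cl)ccc2C(=O)N1c1cccnc1` is not yet measured. It differs from compound 3 by hydrogen in place of methyl on a saturated ring carbon. Within the data shown here, this is the same kind of change as the one from compound 1 to compound 2, not the same one: in compound 1 the carbon sits in a six-membered non-aromatic ring, two ring bonds from the ring nitrogen and two ring bonds from the ring atom that bears the pyridin-3-yl group, whereas in compound 3 it sits in a five-membered non-aromatic ring, next to the ring nitrogen and next to the ring atom that bears the pyridin-3-yl group.

Because the earlier step was a 9.4-fold lower number from compound 1 to compound 2 (0.97 log units; beyond the scatter), the step from compound 3 to compound 4 in this assay is expected to go the same way, but more modestly, since the surroundings differ and compound 3 already starts lower; the expected step is a 3.1-fold lower number from compound 3 to compound 4 (0.49 log units; beyond the scatter). Compound 4 is thus estimated at 35 nM, with a plausible range from 10 nM to 150 nM.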

Compound 4, half-maximal inhibitory concentration: 123 nM
Estimate against measurement, compound 4: 3.5-fold (0.55 log units) below; the range from low to high includes it.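

In this assay, hydrogen in place of methyl on the saturated ring carbon of the five-membered non-aromatic ring gives a 1.1-fold higher number from compound 3 to compound 4 (0.06 log units; within the scatter), so compound 3 and compound 4 cannot be ordered. Within the data shown here, the change therefore does not carry over as a fixed step from the core of compound 1 to the core of compound 3, and the large step seen on the first core is no guide to the second: the same change on two cores in this assay, a 9.4-fold lower number (0.97 log units; beyond the scatter) from compound 1 to compound 2 and a 1.1-fold higher number (0.06 log units; within the scatter) from compound 3 to compound 4, 11-fold (1.03 log units) apart, beyond the scatter of two such steps. This rests on a single pair per core, so it shows that the size of the step depends on the core in these two cases, but it does not show what in the cores produces the difference, nor how the same change would behave on any third core.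

Still open, on these data alone, is whether a larger or different group on the same saturated ring carbon, such as an ethyl chain, a hydroxymethyl group or an amine, would separate from hydrogen and methyl on either core. Also open, as far as these compounds go, is whether the contrast between the two cores would persist if the chlorine gave way to a nitrile or the pyridin-3-yl group to another ring.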